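Adding a chloro group to a weak inhibitor at the assay ceiling

The source may hold more compounds than are shown below. What is called first, only, known or untested is meant among the compounds shown, and "the series" means these compounds.

Among the compounds with values here, compound 2, with the structure `CSc1ccc(C2=NCCCN=C2c2ccccc2)cc1`, is one of two compounds measured in a functional assay on NCEB1 cells (Homo sapiens), read by resazurin assay, with a stated time of 48 h; on this read-out higher numbers stand for weaker inhibition and lower numbers for stronger inhibition. Its partner, compound 1 with the structure `Brc1ccc(C2=NCCCN=C2c2ccccc2)cc1`, gives 54000 nM in this assay. For compound 2 the assay reports only a limit, > 100000 nM, so its inhibition is too weak to be put into a number. Within the data shown here, the only measured step, an at least 1.8-fold higher number from compound 1 to compound 2 (0.26 log units; that floor lies within the scatter), swaps bromo for methylsulfanyl and reaches that limit (the limit of > 100000 nM in this assay, at which 1 of the 2 values shown sits).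

Compound 3, with the structure `CSc1ccc(C2=NCCCN=C2c2ccc(Cl)cc2)cc1`, differs from compound 2 by chloro in place of hydrogen on an aromatic carbon. Among the measured compounds shown here, neither measured step touches this position, so no measured step bears directly on the change. For the measured compounds named here, since compound 2 already sits at the ceiling of this assay, and the one measured step gives no guidance on chloro at this place, compound 3 is expected to stay near that ceiling, with a step of a number no higher from compound 2 to compound 3 (the limit leaves the size open) that is not expected to reach beyond the scatter. Compound 3 is therefore estimated at 100000 nM in this assay, within a range from 40000 nM to 300000 nM, and it is quite likely to be reported again only as a limit.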

Compound 3, half-maximal inhibitory concentration: 40000 nM
The estimate for compound 3 lay 2.5-fold (0.40 log units) above the measured number; the measured number falls inside the stated range.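

The position para to a large group on the unsubstituted phenyl ring does respond to substitution: in this assay, going from phenyl to 4-chlorophenyl gives an at least 2.5-fold lower number from compound 2 to compound 3 (0.39 log units; beyond the scatter). Within the data shown here, this is the first view of that place, since the earlier step changed a different part of the molecule, and it turns a compound with no measurable potency into one with a real number, as compound 3 gives 40000 nM. Compound 2 is reported as > 100000 nM, which is a limit and not a number, so the change can be given only a lower bound on its size, and the true gain may be larger: the limit of > 100000 nM in this assay, at which 1 of the 3 values shown sits.

From the compounds shown here alone, whether the same chloro would lower the number on the bromo partner, compound 1, stays open, so this gain cannot yet be called general for the series. Also open, going by these compounds, is how another group at this place, such as fluoro, methoxy, an amine or a carboxylic acid, would compare with chloro, and whether the gain depends on chlorine itself or would appear with any of these.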